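Adding a Propoxy Group to Compound 1

The source may report more compounds than this note shows. Statements on the series, on what has been measured and on what is new or still open speak of the compounds shown alone.

Compound 1 `FC(F)(F)c1ccc2[nH]c(-c3ccccc3)nc2c1`: 91.2%
Compound 2 `COc1cc(-c2nc3cc([N+](=O)[O-])ccc3[nH]2)ccc1O`: 91.7%

In a functional assay on aorta (Rattus norvegicus, strain Wistar) for inhibition, with a stated time of 60 min (a higher number here means a larger maximal response, a lower number a smaller maximal response), compound 1 gives 91.2%, and compound 2 gives 91.7%. Within the data shown here, the two values lie within the usual scatter of each other, so compound 1 stands level with the only other measured compound. Compound 3 `CCCOc1ccc(-c2nc3cc(C(F)(F)F)ccc3[nH]2)cc1` has not yet been measured. It differs from compound 1 in one place: propoxy in place of hydrogen on an aromatic carbon. Among the measured compounds shown here, no comparison between measured compounds exists that would show what such a change does here. Both measured values sit near the top of the scale. The step of a number 1.2 percentage points lower from compound 1 to compound 3 (within the scatter) is therefore expected to stay within the scatter. Compound 3 is estimated to give 90%, between 75% and 99%.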

Compound 3, largest response reached (Emax), in percent of the reference or control that the assay uses: 51%
Estimate against measurement, compound 3: 39 percentage points above, and the stated range ends above it.
By their numbers in this assay, from the lowest: compound 3; then compounds 1 and 2 (each within the scatter of the next).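

In this assay propoxy in place of hydrogen on an aromatic carbon, para to a large group, gives a number 40.2 percentage points lower from compound 1 to compound 3 (beyond the scatter) and thus a large change. Among these compounds, this shows that the maximal response depends on what sits at this position, which the earlier compounds could not show, as they offered no comparison differing in one place. Nothing at hand accounts for the size of this step. The compounds shown leave open whether a methoxy group, a longer butoxy chain or an amine on the same carbon would lower the response as far. They also leave open whether the oxygen or the chain goes with the step.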